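Half-life after removing a ring-nitrogen methyl

The compounds below may be only part of what the source reports. "The series", "measured", "known", "first", "only" and "open" are said of these compounds alone.

Compound 1 `CC(C)(C)n1nc(Cc2cccc(Cl)c2)c2c(N)ncnc21`: 0.0667 h
Compound 2 `Nc1ncnc2c1c(Cc1cc(F)cc(F)c1)nn2CC1CCNCC1`: > 1 h
Compound 3 `CN1CCC(Cn2nc(Oc3cccc(Cl)c3)c3c(N)ncnc32)CC1`: > 1 h

All three compounds were tested in an ADME assay on microsomes from liver (Rattus norvegicus) for metabolic stability, read by LC-MS, tested at 1 uM; on this read-out lower numbers stand for a shorter-lived compound and higher numbers for a longer-lived compound. Only compound 1 gives a number there, 0.0667 h. Compound 3 reads > 1 h, and this is a limit, not a number. Compound 3 therefore stands at the limit of > 1 h in this assay, at which 2 of the 3 values shown sit.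

Compound 4 `Nc1ncnc2c1c(Oc1cccc(Cl)c1)nn2CC1CCNCC1` has not yet been measured. It departs from compound 3 in one place: hydrogen in place of methyl on an amine nitrogen in a ring. This is hydrogen in place of methyl on an amine nitrogen in a ring, turning (1-methylpiperidin-4-yl)methyl into (piperidin-4-yl)methyl.

Compound 2 already carries (piperidin-4-yl)methyl, though with a different group elsewhere on the shared core, and the expectation of little change rests on compound 2, which reads > 1 h, also a limit. The expected change in this assay stays within the scatter, with no clear direction: a step that the limit leaves unreadable from compound 3 to compound 4 is the estimated step. The estimate for compound 4 is 1.3 h, with an expected range of 0.6 h to 3 h.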

Compound 4, half-life: > 1 h
Compound 4: no number, only a limit (the forecaster's own chance of this, stated with the estimate: 70%); the middle value lies beyond the limit too.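

In this assay compound 3 and compound 4 both give only limits, so no step can be read between them: the limit of > 1 h in this assay, at which 3 of the 4 values shown sit. The compounds shown leave open how far either half-life lies past that limit, and whether hydrogen in place of methyl changes it at all.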